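Replacing a methylamino group with a ring on compound 3

The compounds below may be only part of what the source reports. "The series", "measured", "known", "first", "only" and "open" are said of these compounds alone.

Compound 3 `CCCCCCCCCCCCN(C)C(=O)Cn1cc(Cc2cnc(=O)n(CC(=O)NC)c2)c(=O)nc1SCc1ccc(F)cc1` gives 28% in a functional assay on a cell-free system (plasma, Oryctolagus cuniculus) for inhibition of platelet-activating factor acetylhydrolase (Homo sapiens), tested at 100 nM (on this read-out higher numbers stand for more inhibition at the one concentration tested (going by the name of the read-out) and lower numbers for less inhibition), the lowest of the three measured numbers; compound 1 `CCCCCCCCCCCCN(C)C(=O)Cn1cc(Cc2cnc(=O)n(CCO)c2)c(=O)nc1SCc1ccc(F)cc1` gives 36%, within the scatter of compound 3, while compound 2 `CCCCCCCCN(C)C(=O)Cn1cc(Cc2cnc(=O)n(CC(=O)N3CCNC(=O)C3)c2)c(=O)nc1SCc1ccc(F)cc1` gives 55%, beyond it. Going by the values given here, the only measured step in this assay, a number 8 percentage points lower from compound 1 to compound 3 (within the scatter), concerns a different change and stays within the scatter. Compound 4 `CCCCCCCCCCCCN(C)C(=O)Cn1cc(Cc2cnc(=O)n(CC(=O)N3CCNC(=O)C3)c2)c(=O)nc1SCc1ccc(F)cc1` arises from compound 3 by 3-oxopiperazin-1-yl in place of methylamino on a carbonyl carbon. Among the compounds with values here, no measured step covers this change; compound 2, which carries the same 3-oxopiperazin-1-yl group on a shorter chain, shows the highest number. A modest rise is therefore expected, a number 12 percentage points higher from compound 3 to compound 4 (beyond the scatter), though it may fall within the scatter. Compound 4 is estimated at 40%, between 25% and 58%.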

Compound 4, a percentage reported as inhibition, at one concentration (the size of the read-out at that concentration, not a potency): 49%
The estimate for compound 4 lay 9 percentage points below the measured number; the measured number falls inside the stated range.
By their numbers in this assay, from the lowest: compounds 3 and 1 (each within the scatter of the next); then compounds 4 and 2 (each within the scatter of the next).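

In this assay, going by these compounds alone, 3-oxopiperazin-1-yl in place of methylamino on this carbonyl carbon gives a step beyond the scatter, which the earlier compounds did not show here: a number 21 percentage points higher from compound 3 to compound 4 (beyond the scatter). The comparison with the hydroxymethyl end group also lies beyond the scatter, a number 13 percentage points higher from compound 1 to compound 4 (beyond the scatter), while butyl in place of hydrogen on the chain stays within it, a number 6 percentage points lower from compound 2 to compound 4 (within the scatter), so these two chain lengths carrying the ring cannot be told apart. Nothing available explains the rise. Going by these compounds, whether a morpholin-4-yl ring or a simple dimethylamino group on the same carbonyl carbon would match 3-oxopiperazin-1-yl remains open.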